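Swapping the Amide Tail for an Aryl Ester

This account rests on a few compounds, and the source may have more. Where it says the series, first, only, none or still open, it means among the compounds named here.

Compound 1 `CCOC(=O)CN(C)C(=O)c1ccc(C(CC)(CC)c2ccc(OCC(=O)C(C)(C)C)c(C)c2)n1CC` reaches only a limit in an assay on HL-60 cells for agonist activity at vitamin D3 receptor (Homo sapiens), read by microscopy, with a stated time of 96 h; a higher number here means that more compound is needed for the effect, a lower number that less compound is needed: compound 1 gives > 50000 nM, which is a limit of the assay and not a number (the limit of > 50000 nM in this assay, at which 1 of the 3 values shown sits). Compound 2 `C#CC(C)OC(=O)c1ccc(C(CC)(CC)c2ccc(OCC(=O)C(C)(C)C)c(C)c2)n1CC` gives 210 nM and compound 3 `CCn1c(C(=O)N(C)CC(=O)O)ccc1C(CC)(CC)c1ccc(OCC(=O)C(C)(C)C)c(C)c1` gives 1390 nM. The change to compound 4 `CCOC(=O)c1ccc(OC(=O)c2ccc(C(CC)(CC)c3ccc(OCC(=O)C(C)(C)C)c(C)c3)n2CC)cc1` is 4-(ethoxycarbonyl)phenoxy in place of ((ethoxycarbonyl)methyl)(methyl)amino on a carbonyl carbon. The most relevant measured step also replaces the same amino group on the carbonyl carbon with an oxygen-linked group, and it was an at least 230-fold lower number from compound 1 to compound 2 (2.37 log units; beyond the scatter); the step of an at least 35-fold lower number from compound 1 to compound 3 (1.55 log units; beyond the scatter) shows that even a smaller change at this tail moves the number far. A large drop is therefore expected for compound 4, an at least 83-fold lower number from compound 1 to compound 4 (1.92 log units; beyond the scatter). Compound 4 is estimated at 600 nM, within a range from 100 nM to 4000 nM.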

Compound 4, half-maximal effective concentration: 45600 nM
Estimate against measurement, compound 4: 76-fold (1.88 log units) below, and the stated range ends below it.
By their numbers in this assay, from the lowest: compound 2; then compound 3; then compound 4. At a limit, above all of these: compound 1.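

An oxygen link on this carbonyl carbon does not by itself bring the number down: 4-(ethoxycarbonyl)phenyl in place of 1-methylprop-2-yn-1-yl on an oxygen next to a carbonyl group gives a 220-fold higher number from compound 2 to compound 4 (2.34 log units; beyond the scatter). The group on that oxygen therefore matters greatly, and the aryl ester also falls behind the amide acid, with a 33-fold higher number from compound 3 to compound 4 (1.52 log units; beyond the scatter). Compound 1 stands at a limit, which is a limit of the assay and not a number: the limit of > 50000 nM in this assay, at which 1 of the 4 values shown sits.

Its step to the aryl ester gives only a floor, an at least 1.0-fold lower number from compound 1 to compound 4 (0.04 log units; that floor lies within the scatter), and the size of that change cannot be read.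

From the compounds shown here alone, whether the 4-(ethoxycarbonyl)phenoxy group fails through its ring or its ester stays open. A plain phenoxy or a simple ethoxy group would separate these.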